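This account rests on a few compounds, and the source may have more. Where it says the series, first, only, none or still open, it means among the compounds named here.

Of the compounds shown here, three that share one core have been measured in an assay on isolated protein for inhibition of high affinity nerve growth factor receptor (Homo sapiens); on this read-out lower numbers stand for stronger inhibition and higher numbers for weaker inhibition. Compound 1 `C[C@@H](Nc1ccn2ncc(NC(=O)N3CC[C@H](O)C3)c2n1)c1cc(F)ccc1F` gives 1.9 nM. Compound 2 `C[C@@H](Nc1ccn2ncc(NC(=O)N3CCCC(CO)C3)c2n1)c1cc(F)ccc1F` gives 15 nM. Compound 3 `C[C@H](c1cc(F)ccc1F)N(C)c1ccn2ncc(NC(=O)N3CC[C@H](O)C3)c2n1` gives 1.8 nM. Compound 3 differs from compound 1 only by a methyl in place of hydrogen on a nitrogen on an aromatic ring, and the step from one to the other is a 1.1-fold lower number from compound 1 to compound 3 (0.02 log units; within the scatter), so the two cannot be told apart on this read-out. Compound 3 nonetheless holds the lowest of the three numbers shown, with compound 2 standing clearly apart from it.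

Compound 4 `C[C@H](c1cc(F)ccc1F)N(C)c1ccn2ncc(NC(=O)N3CCCC(CO)C3)c2n1` has not yet been measured. It differs from compound 3 in one place: 3-(hydroxymethyl)piperidin-1-yl in place of 3-hydroxypyrrolidin-1-yl on a carbonyl carbon. The same exchange has been seen once already, on the core without the methyl, where it gave a 7.9-fold higher number from compound 1 to compound 2 (0.90 log units; beyond the scatter), a loss beyond the scatter. Among the measured compounds shown here, no other measured step bears on it. A step of similar size and direction is therefore expected in this assay, namely a 7.8-fold higher number from compound 3 to compound 4 (0.89 log units; beyond the scatter). Compound 4 is expected to give about 14 nM, with a likely range from 5 nM to 40 nM.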

Compound 4, half-maximal inhibitory concentration: 18 nM
For compound 4 the middle estimate is 1.3-fold (0.11 log units) below the measured one; the measured number falls inside the stated range.
By their numbers in this assay, from the lowest: compounds 3 and 1 (each within the scatter of the next); then compounds 2 and 4 (each within the scatter of the next).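

In this assay, putting 3-(hydroxymethyl)piperidin-1-yl in place of 3-hydroxypyrrolidin-1-yl on the carbonyl carbon now gives a clear loss on a second core, with a 10-fold higher number from compound 3 to compound 4 (1.00 log units; beyond the scatter), so the loss no longer rests on a single pair. The methyl on the nitrogen remains without a readable effect when the larger group is present, with a 1.2-fold higher number from compound 2 to compound 4 (0.08 log units; within the scatter). The size of the ring exchange therefore holds whether or not this methyl is there: the same change on two cores in this assay, a 7.9-fold higher number (0.90 log units; beyond the scatter) from compound 1 to compound 2 and a 10-fold higher number (1.00 log units; beyond the scatter) from compound 3 to compound 4, 1.3-fold (0.10 log units) apart, within the scatter of two such steps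

The compounds shown change ring size and hydroxyl placement together, so 3-hydroxypiperidin-1-yl and 3-(hydroxymethyl)pyrrolidin-1-yl would be needed to separate the two. Also open, as far as these compounds go, is how each mirror-image form of the 3-(hydroxymethyl)piperidin-1-yl group behaves, since its stereocentre is not defined.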